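Branched Alkyl in Place of Benzyloxy on the Carbonyl

The source may hold more compounds than are shown below. What is called first, only, known or untested is meant among the compounds shown, and "the series" means these compounds.

Three compounds have been measured in an assay on COS-7 cells for inhibition of patatin-like phospholipase domain-containing protein 2 (Mus musculus), tested at 200 uM; a lower number here means less inhibition, a higher number more inhibition at the concentration tested (going by the name of the read-out):
compound 1, `CC(C)COC(=O)Nc1cccc(-c2ccc(N(C)C)cc2)c1`, gives 90%;
compound 2, `CN(C)c1ccc(-c2cccc(NC(=O)Oc3ccccc3)c2)cc1`, gives 75%;
compound 3, `CN(C)c1ccc(-c2cccc(NC(=O)OCc3ccccc3)c2)cc1`, gives 50%.

Compound 3 stands lowest of the three; its nearest neighbour is compound 2, and compound 1 is furthest from it. The measured steps all lie beyond the scatter: a number 15 percentage points lower from compound 1 to compound 2 (beyond the scatter), a number 40 percentage points lower from compound 1 to compound 3 (beyond the scatter) and a number 25 percentage points lower from compound 2 to compound 3 (beyond the scatter). Taken together, the branched alkyl carbamate of compound 1 stands highest and the benzyl carbamate of compound 3 lowest in this assay.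

Compound 4, `CN(C)c1ccc(-c2cccc(NC(=O)C(C)(C)C)c2)cc1`, differs from compound 3 as follows: tert-butyl in place of benzyloxy on a carbonyl carbon. The step from compound 1 to compound 3 bears on this change most closely, since it also exchanges a branched alkyl group for a benzyl-type group, and it was large. Among the compounds with values here, the step from compound 3 to compound 4, however, also removes the oxygen of the carbamate, and no measured pair speaks to that. Compound 4 is therefore expected to sit above compound 3, with a step of a number 20 percentage points higher from compound 3 to compound 4 (beyond the scatter), though with wide uncertainty. The estimate for compound 4 in this assay is 70%, ranging from 40% to 90%.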

Compound 4, a percentage reported as inhibition, at one concentration (the size of the read-out at that concentration, not a potency): 25%
Compound 4: middle estimate off by 45 percentage points, on the high side, outside the stated range (below it).
By their numbers in this assay, from the lowest: compound 4; then compound 3; then compound 2; then compound 1.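

In this assay the amide compound 4 falls below all three carbamates, with a number 25 percentage points lower from compound 3 to compound 4 (beyond the scatter) and a number 50 percentage points lower from compound 2 to compound 4 (beyond the scatter) and also a number 65 percentage points lower from compound 1 to compound 4 (beyond the scatter) as the exchanges on the carbonyl carbon. The earlier compounds shown here varied only the group carried through the oxygen on the carbonyl, and among them the branched isobutoxy of compound 1 stood highest, whereas the branched tert-butyl of compound 4 now stands lowest, so a branched alkyl group does not by itself go with a high number across these four compounds. Nothing available accounts for this fall.

The compounds shown leave open whether the loss follows from removing the oxygen or from the tert-butyl group itself, since each step to compound 4 changes both together, and tert-butoxy on the carbonyl carbon would separate the two. As far as these compounds go, how a urea with an amine on the carbonyl carbon, or an amide with a longer straight chain there, would stand against compound 4 also remains open.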